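This account rests on a few compounds, and the source may have more. Where it says the series, first, only, none or still open, it means among the compounds named here.

In a functional assay on OVCAR-5 cells (Homo sapiens) for inhibition, read by sulforhodamine B assay, with a stated time of 48 h (on this read-out lower numbers stand for stronger inhibition of growth and higher numbers for weaker inhibition of growth), compound 2 `COc1ccc(C(=O)/C=C/c2cc(-c3cc(OC)c(OC)c(OC)c3)n[nH]2)cc1` gives 1880 nM. Going by the values given here, only one other compound has been measured alongside it: compound 1 `COc1cc(-c2cc(/C=C/C(=O)c3ccc(N)cc3)[nH]n2)cc(OC)c1OC`, which in this assay gives 1780 nM. The two numbers fall within the usual scatter of each other, so neither compound can be called the stronger. Among the compounds with values here, the single measured step between them is a 1.1-fold higher number from compound 1 to compound 2 (0.02 log units; within the scatter).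

Compound 3 `COc1cc(-c2cc(/C=C/C(=O)c3ccc(F)c(F)c3)[nH]n2)cc(OC)c1OC` is the next compound, and it differs from compound 2 in one place: 3,4-difluorophenyl in place of 4-methoxyphenyl on a carbonyl carbon. Within the data shown here, no measured step involves a fluorinated ring, so the data bear on this change only indirectly: the one step in hand, a 1.1-fold higher number from compound 1 to compound 2 (0.02 log units; within the scatter), shows that swapping amino for methoxy on an aromatic carbon left the number essentially unchanged. On that slim basis compound 3 is expected to give a number close to that of compound 2, with no step beyond the scatter in either direction, and the expected step is a 1.1-fold higher number from compound 2 to compound 3 (0.03 log units; within the scatter). The estimate for compound 3 in this assay is therefore 2000 nM, with a range from 700 nM to 6000 nM.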

Compound 3, concentration for 50% growth inhibition: 4480 nM
Estimate against measurement, compound 3: 2.2-fold (0.35 log units) below; the measured number falls inside the stated range.
By their numbers in this assay, from the lowest: compounds 1 and 2 (each within the scatter of the next); then compound 3.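

At the ring on the carbonyl carbon, this assay does respond to the group placed there: 3,4-difluorophenyl in place of 4-methoxyphenyl gives a 2.4-fold higher number from compound 2 to compound 3 (0.38 log units; beyond the scatter), and the same group in place of 4-aminophenyl gives a 2.5-fold higher number from compound 1 to compound 3 (0.40 log units; beyond the scatter), both modest but beyond the scatter. The earlier swap of amino for methoxy had shown no change beyond the scatter, so compound 3 is the first sign that this place can separate compounds, with 3,4-difluorophenyl giving weaker growth inhibition than either 4-methoxyphenyl or 4-aminophenyl. No measurement at hand explains why the number rises with this change.

The compounds shown leave open whether the weaker result goes with fluorine as such or with this particular pair of fluorines, a question that a ring carrying a single fluorine or a plain phenyl ring could help to settle. They also leave open how other groups on this ring would compare, such as a chlorine, a nitrile or a carboxylic acid.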